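A few compounds are considered here, and "the series" means these few. Any claim that something is new, unique, unknown or untested is made for them only; others in the source may bear on it.

Working notes. Within the data shown here, in an assay on U2OS cells for activation of nuclear factor erythroid 2-related factor 2 (Homo sapiens), read by beta-arrestin recruitment, with a stated time of 6 h (on this read-out higher numbers stand for an effect only at larger amounts of compound and lower numbers for an effect already at smaller amounts), compound 1 `O=S(=O)(/C=C/c1ccccn1)c1cccc(F)c1` gives 1680 nM and compound 2 `O=S(=O)(/C=C/c1ccccn1)c1cccc(Cl)c1` gives 1430 nM; the single measured step, a 1.2-fold lower number from compound 1 to compound 2 (0.07 log units; within the scatter), lies within the scatter. Compound 2 therefore holds the lowest of the two numbers, but its gap to compound 1 is within the scatter. Compound 3 `O=S(=O)(/C=C/c1ncccc1Cl)c1cccc(Cl)c1` differs from compound 2 by chloro in place of hydrogen on an aromatic carbon. Among the measured compounds shown here, no measured step concerns a change of this kind; the one known step was within the scatter and bears on it only loosely. For compound 3 in this assay, an expected step of a 1.0-fold lower number from compound 2 to compound 3 (0.01 log units; within the scatter), not beyond the scatter, gives an estimate of 1400 nM with a range from 500 nM to 4000 nM.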

Compound 3, half-maximal effective concentration: 46 nM
Compound 3: the middle estimate sits 30-fold (1.48 log units) above what was measured, and the stated range ends above it.
By their numbers in this assay, from the lowest: compound 3; then compounds 2 and 1 (each within the scatter of the next).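

In this assay, one chloro in place of hydrogen, on the aromatic carbon ortho to a large group and two atoms from the ring nitrogen, gives a 31-fold lower number from compound 2 to compound 3 (1.49 log units; beyond the scatter), a large step. The earlier change, a 1.2-fold lower number from compound 1 to compound 2 (0.07 log units; within the scatter), showed no such response, so this position is far more sensitive to substitution than that step suggested. Nothing available explains the size of this step. Open, going by these compounds, is whether the lower number is specific to chloro or also follows with methyl, methoxy or an amine at this position.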